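Isoquinoline for Benzothiazole in a Liver Microsome Stability Series

A few compounds are considered here, and "the series" means these few. Any claim that something is new, unique, unknown or untested is made for them only; others in the source may bear on it.

Of the compounds shown here, three have been measured in an ADME assay on microsomes from liver (Mus musculus) for metabolic stability, read by LC-MS, with a stated time of 10 min, tested at 0.5 uM; on this read-out lower numbers stand for a less stable compound and higher numbers for a more stable compound. Compound 1 `c1ccc2c(c1)CN[C@@H](CN(CC[C@H]1CCCNC1)[C@H]1CCCc3cccnc31)C2` gives 56%, the highest of the three. Compound 2 `c1cnc2c(c1)CCC[C@@H]2N(CCCN1CCNCC1)Cc1nc2ccccc2s1` gives 45%, the second highest number; it sits nearest to compound 1 and furthest from compound 3 `CCN1CCN(CCCN(C[C@H]2Cc3ccccc3CN2)[C@H]2CCCc3cccnc32)CC1`, which gives 19%. Among the compounds with values here, the one step measured at a single place is a number 37 percentage points lower from compound 1 to compound 3 (beyond the scatter), a large fall.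

Compound 4 `c1cnc2c(c1)CCC[C@@H]2N(CCCN1CCNCC1)Cc1cc2ccccc2cn1` differs from compound 2 at another place: isoquinolin-3-yl in place of 1,3-benzothiazol-2-yl on a saturated chain carbon bound to an amine nitrogen. The fall from compound 1 to compound 3 concerns the other end of the chain and does not speak to this exchange of aromatic groups at the carbon bound to the amine nitrogen. Within the data shown here, no measured pair shows what swapping these two groups does in this assay. Given that, compound 4 is expected to stay close to compound 2, with a step of a number 5 percentage points lower from compound 2 to compound 4 (within the scatter), likely within the scatter. The estimate for compound 4 is 40%, in the range 20% to 60%.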

Compound 4, percent of the compound remaining: 74%
Estimate against measurement, compound 4: 34 percentage points below; the whole stated range lies below it.
By their numbers in this assay, from the lowest: compound 3; then compound 2; then compound 1; then compound 4.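

In this assay, within the data shown here, isoquinolin-3-yl in place of 1,3-benzothiazol-2-yl on a saturated chain carbon bound to an amine nitrogen gives a number 29 percentage points higher from compound 2 to compound 4 (beyond the scatter), so this place, which the earlier compounds left untouched, clearly bears on the read-out. The change removes a five-membered aromatic ring with 2 hetero atoms, sulfur among them, and brings in a six-membered aromatic ring with 1 hetero atom, while the rest of the molecule stays the same. Nothing measured on these compounds explains the rise.

As far as these compounds go, it remains open whether the rise belongs to isoquinolin-3-yl itself or to the loss of the sulfur-bearing ring, which a group such as 1,3-benzoxazol-2-yl or quinolin-2-yl at this place could help separate. From the compounds shown here alone, it is also open whether the same exchange would give a similar step with (4-ethylpiperazin-1-yl)methyl at the other end of the chain.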